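The source may hold more compounds than are shown below. What is called first, only, known or untested is meant among the compounds shown, and "the series" means these compounds.

Measured compounds:
compound 1 `O=C(Nc1ccc([N+](=O)[O-])cc1)c1cc(F)ccc1O`, 520 nM
compound 2 `N#Cc1ccc(NC(=O)c2cc(Cl)ccc2O)cc1`, 700 nM
compound 3 `N#Cc1ccc(NC(=O)c2ccccc2O)cc1`, 4620 nM

All numbers come from a functional assay on HL-60 cells (Homo sapiens) for cytotoxicity, read by luminescence and CellTiter-Glo, with a stated time of 3 days; a higher number here means a weaker inhibitor, a lower number a stronger inhibitor. In this assay compound 3 gives 4620 nM and compound 2 gives 700 nM; the change between them, (chloro in place of hydrogen on an aromatic carbon), made the step of a 6.6-fold lower number from compound 3 to compound 2 (0.82 log units; beyond the scatter). Compound 1 gives 520 nM, the lowest number of the three; its gap to compound 2 lies within the scatter, its gap to compound 3 beyond it. The difference between the core of compound 1 and the core of compound 3 is not broken down here.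

Compound 4 `O=C(Nc1ccc([N+](=O)[O-])cc1Cl)c1cc(F)ccc1O` is not yet measured. It differs from compound 1 by chloro in place of hydrogen on an aromatic carbon. For the measured compounds named here, this is the same kind of change as the one from compound 3 to compound 2, but not the same: there the chloro sits meta to a large group and para to a hydroxy group, here ortho to a large group and meta to a nitro group. One prior instance at another place is thin ground. A smaller step is expected than a 6.6-fold lower number from compound 3 to compound 2 (0.82 log units; beyond the scatter). In this assay compound 4 is expected to give 300 nM, within 100 nM to 900 nM. The expected step is a 1.7-fold lower number from compound 1 to compound 4 (0.24 log units; within the scatter).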

Compound 4, half-maximal inhibitory concentration: 280 nM
Compound 4: middle estimate off by 1.1-fold (0.03 log units), on the high side; the measured number falls inside the stated range.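

In this assay, chloro in place of hydrogen on an aromatic carbon, ortho to a large group and meta to a nitro group, gives a 1.9-fold lower number from compound 1 to compound 4 (0.27 log units; within the scatter), a step that cannot be told apart from repeat measurements. The change does not carry from one core to another with a single size: the same change on two cores in this assay, a 6.6-fold lower number (0.82 log units; beyond the scatter) from compound 3 to compound 2 and a 1.9-fold lower number (0.27 log units; within the scatter) from compound 1 to compound 4, 3.6-fold (0.55 log units) apart, beyond the scatter of two such steps. The two steps differ both in the core and in the place of the chloro; the data cannot tell which of these sets the gap, and two steps give no rule for a further core.

Open, going by these compounds, is whether a methyl, a methoxy or an amine in the place of this chloro would give a step of similar size. Also open, on these data alone, is how the nitro group and the nitrile compare on a matched core, and how the fluoro and the chloro compare there; compound 1 and compound 2 differ in both places at once.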